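The source may report more compounds than this note shows. Statements on the series, on what has been measured and on what is new or still open speak of the compounds shown alone.

Compounds measured so far:
- compound 1, `COc1ccccc1C(=O)/C=C/c1ccc2ccccc2c1`, 460 nM
- compound 2, `CCCOc1ccccc1C(=O)/C=C/c1ccc2ccccc2c1`, 100 nM
- compound 3, `CCCCOc1ccccc1C(=O)/C=C/c1ccc2ccccc2c1`, 120 nM

In a functional assay on OCI-Ly7 cells (Homo sapiens) for cytotoxicity, with a stated time of 48 h (on this read-out lower numbers stand for stronger inhibition and higher numbers for weaker inhibition), compound 1 gives the highest of the three numbers; its nearest neighbour is compound 3, with a 3.8-fold lower number from compound 1 to compound 3 (0.58 log units; beyond the scatter), and compound 2 lies furthest, with a 4.6-fold lower number from compound 1 to compound 2 (0.66 log units; beyond the scatter). Between compound 2 and compound 3 the gap is a 1.2-fold higher number from compound 2 to compound 3 (0.08 log units; within the scatter), so the two longer chains cannot be told apart.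

Compound 4, `Cc1ccccc1C(=O)/C=C/c1ccc2ccccc2c1`, differs from compound 1 by methyl in place of methoxy on an aromatic carbon. Among the compounds with values here, none of the measured steps bears directly on this change: all three concern lengthening the saturated chain on the oxygen, and the two steps from compound 1 that go beyond the scatter both add carbons to that chain rather than removing the oxygen. The present change goes the other way, shrinking the group and taking away its hydrogen-bond acceptor, so there is no measured basis for expecting a lower number. The estimate for compound 4 is therefore placed near compound 1, with a step of a 1.2-fold higher number from compound 1 to compound 4 (0.08 log units; within the scatter) that is expected to lie within the scatter. Compound 4 is expected to give 550 nM in this assay, within a range of 200 nM to 1500 nM.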

Compound 4, half-maximal inhibitory concentration: 4900 nM
Compound 4: middle estimate off by 8.9-fold (0.95 log units), on the low side, outside the stated range (above it).
By their numbers in this assay, from the lowest: compounds 2 and 3 (each within the scatter of the next); then compound 1; then compound 4.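

Replacing methoxy with methyl on this aromatic carbon, ortho to a large group, has a large effect in this assay, giving an 11-fold higher number from compound 1 to compound 4 (1.03 log units; beyond the scatter) and showing that the group at this place matters well beyond the changes in chain length seen earlier. Measured against the longer chains, the same place gives a 41-fold higher number from compound 3 to compound 4 (1.61 log units; beyond the scatter) and a 49-fold higher number from compound 2 to compound 4 (1.69 log units; beyond the scatter), so all three compounds with an alkoxy group here give lower numbers than compound 4, and no compound shown goes against this. Nothing available explains why the methyl compound gives so much higher a number.

The compounds shown do not separate the oxygen from the carbon chain that it carries, so it remains open whether an ethyl or propyl group on this aromatic carbon would behave like compound 4 or like the alkoxy compounds. As far as these compounds go, how a hydroxyl group, an amine or a chain longer than butoxy would compare at this place also remains open, as does whether the same pattern would hold on a different core.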